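The source may report more compounds than this note shows. Statements on the series, on what has been measured and on what is new or still open speak of the compounds shown alone.

Among the compounds with values here, compound 2 `Nc1nn(Cc2cn(CC(=O)Nc3cccc(Cl)c3)nn2)c2nc(-c3ccccc3)cc(C(F)(F)F)c12` gives 37 ug/mL in a functional assay on THP-1 cells (Homo sapiens) for cytotoxicity, read by MTT assay, with a stated time of 24 h (on this read-out lower numbers stand for stronger inhibition and higher numbers for weaker inhibition), one of two numbers so far; compound 1 `CCCCn1cc(Cn2nc(N)c3c(C(F)(F)F)cc(-c4ccccc4)nc32)nn1` gives 46.1 ug/mL, and the step of a 1.2-fold lower number from compound 1 to compound 2 (0.10 log units; within the scatter) lies within the scatter. Compound 3 `Cc1ccc(NC(=O)Cn2cc(Cn3nc(N)c4c(C(F)(F)F)cc(-c5ccccc5)nc43)nn2)cc1` differs from compound 2 by 4-methylphenyl in place of 3-chlorophenyl on an amide-type nitrogen. Within the data shown here, no measured step changes the group on this amide nitrogen; the only step known, a 1.2-fold lower number from compound 1 to compound 2 (0.10 log units; within the scatter), alters a different part of the molecule and is small. For compound 3 the expected step of no change at the digits printed from compound 2 to compound 3 (within the scatter) is therefore none beyond the scatter. Compound 3 is estimated at 37 ug/mL, with a range from 18 ug/mL to 75 ug/mL.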

Compound 3, half-maximal inhibitory concentration: 41.5 ug/mL
The estimate for compound 3 lay 1.1-fold (0.05 log units) below the measured number, and the stated range covers the measured number.
By their numbers in this assay, from the lowest: compounds 2, 3 and 1 (each within the scatter of the next).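

Within the data shown here, on the amide-type nitrogen, 4-methylphenyl in place of 3-chlorophenyl gives a 1.1-fold higher number from compound 2 to compound 3 (0.05 log units; within the scatter) in this assay, the first reading of a change at this position. Against the propyl of compound 1, the (4-methylphenyl)carbamoyl group gives a 1.1-fold lower number from compound 1 to compound 3 (0.05 log units; within the scatter), so neither carbamoyl compound is separated from compound 1. Nothing available bears on a cause for these steps.

On these data alone, whether a carboxylic acid or an amine on this phenyl ring, or a longer chain in its place, would shift the number beyond the scatter remains open.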